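A few compounds are considered here, and "the series" means these few. Any claim that something is new, unique, unknown or untested is made for them only; others in the source may bear on it.

Measured so far in this series:

Compound 1, `COc1cc2nc(N3CCN(S(=O)(=O)c4ccc(-c5ccccc5)cc4)CC3)nc(N)c2cc1OC`: 4200 nM
Compound 2, `COc1cc2nc(N3CCN(S(=O)(=O)c4ccc(-c5ccc(C)cc5)cc4)CC3)nc(N)c2cc1OC`: 3400 nM

In a functional assay on PC-3 cells (Homo sapiens) for inhibition (a higher number here means a weaker inhibitor, a lower number a stronger inhibitor), compound 1 gives 4200 nM, and compound 2 gives 3400 nM. Among the measured compounds shown here, compound 2 thus carries the lower of the two numbers, but the only step between them, a 1.2-fold lower number from compound 1 to compound 2 (0.09 log units; within the scatter), lies within the scatter, so the two compounds are not separable on these data.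

Compound 3, `COc1cc2nc(N3CCN(S(=O)(=O)c4ccc(-c5ccc(C(F)(F)F)cc5)cc4)CC3)nc(N)c2cc1OC`, differs from compound 2 by trifluoromethyl in place of methyl on an aromatic carbon. For the measured compounds named here, no measured step in this assay involves a trifluoromethyl group; the single step available, from hydrogen to methyl at the same aromatic carbon, was small and within the scatter. Going by the values given here, with no direct precedent, the account expects no step beyond the scatter from compound 2 to compound 3, that is a 1.1-fold lower number from compound 2 to compound 3 (0.05 log units; within the scatter), with a wide allowance in both directions. For compound 3 in this assay the estimated value is 3000 nM, expected to fall between 1200 nM and 8000 nM.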

Compound 3, half-maximal inhibitory concentration: 3300 nM
Estimate against measurement, compound 3: 1.1-fold (0.04 log units) below; low and high end bracket the measured number.
By their numbers in this assay, from the lowest: compounds 3, 2 and 1 (each within the scatter of the next).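

In this assay, the 4-methylphenyl and 4-(trifluoromethyl)phenyl forms cannot be told apart (a 1.0-fold lower number from compound 2 to compound 3 (0.01 log units; within the scatter)), and the trifluoromethyl group also stays within the scatter of the hydrogen it stands in place of (a 1.3-fold lower number from compound 1 to compound 3 (0.10 log units; within the scatter)). At this aromatic carbon, para to a large group, hydrogen, methyl and trifluoromethyl are therefore not separable, so the position takes a group of four heavy atoms in place of methyl's one without a readable difference in the number. Nothing available bears on why these three compounds read alike.

From the compounds shown here alone, it remains open whether a group of another kind on this carbon, such as an amine, a carboxylic acid or a longer chain, would separate from these three. The compounds shown also do not tell whether any change to the sulfonyl, the piperazine or the shared core would do so.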